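Swapping one aromatic group on the higher-numbered compound

The compounds below may be only part of what the source reports. "The series", "measured", "known", "first", "only" and "open" are said of these compounds alone.

In a functional assay on MDA-MB-231 cells (Homo sapiens) for inhibition, read by CellTiter-Glo, with a stated time of 72 h (a lower number here means that less compound is tolerated, a higher number that more compound is tolerated), compound 1 (`CC1=C(CC(=O)N(C)CCN(C)C)c2cc(F)ccc2/C1=C\c1nc2ccccc2s1`) gives 3800 nM and compound 2 (`CC1=C(CC(=O)N2CCN(CCCN(C)C)CC2)c2cc(F)ccc2/C1=C\c1ccc([S+](C)[O-])cc1`) gives 46200 nM as the higher of the two numbers. Moving to compound 3 (`CC1=C(CC(=O)N2CCN(CCCN(C)C)CC2)c2cc(F)ccc2/C1=C\c1nc2ccccc2s1`) brings a group of 9 heavy atoms (7 carbon, 1 nitrogen, 1 sulfur; one five-membered aromatic ring with 2 hetero atoms, one six-membered aromatic ring of carbon only) in place of a group of 9 heavy atoms (7 carbon, 1 oxygen, 1 sulfur; one six-membered aromatic ring of carbon only), on a double-bonded chain carbon bound to a double-bonded ring carbon as the single change, and the entering 1,3-benzothiazol-2-yl group is one that compound 1 already carries. Compound 1 at 3800 nM has a different chain on its amide, so it is only a rough guide, but it points to a drop beyond the scatter in this assay. The expected move is a 12-fold lower number from compound 2 to compound 3 (1.06 log units; beyond the scatter) in all. For compound 3 the estimated value is 4000 nM within a range of 1000 nM to 15000 nM as expected here.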

Compound 3, half-maximal cytotoxic concentration: 2900 nM
Beside the measured number, compound 3's estimate is 1.4-fold (0.14 log units) above it; measured number inside the range.
By their numbers in this assay, from the lowest: compounds 3 and 1 (each within the scatter of the next); then compound 2.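

In this assay, the 1,3-benzothiazol-2-yl group on the double-bonded chain carbon bound to a double-bonded ring carbon gives a 16-fold lower number from compound 2 to compound 3 (1.20 log units; beyond the scatter), so this single place strongly affects the number. Changing the amide group to 4-(3-(dimethylamino)propyl)piperazin-1-yl gives a 1.3-fold lower number from compound 1 to compound 3 (0.12 log units; within the scatter), so with this aromatic group the two amide chains cannot be told apart. No measurement here explains the large step. From the compounds shown here alone, whether a plain phenyl or 1,3-benzoxazol-2-yl group would give a similarly low number remains open, as does what a longer amine chain on the amide would do.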